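The source may report more compounds than this note shows. Statements on the series, on what has been measured and on what is new or still open speak of the compounds shown alone.

Values in a functional assay on a cell-free system (plasma, Oryctolagus cuniculus) for inhibition, with stated times of 5 min, 1 min and 6 min; a higher number here means a weaker inhibitor, a lower number a stronger inhibitor:
- compound 1 `CCOC(=O)c1c(C)nc(-c2cccc(C#N)c2)n1O`: 17600 nM
- compound 2 `CCOC(=O)c1c(C)nc(-c2cccc(C#N)c2)n1OCc1ccccc1`: 5930 nM
- compound 3 `CCOC(=O)c1c(C)nc(-c2cccc(C#N)c2)n1OCc1ccc(Br)cc1`: 24600 nM

Compound 3 sits within the scatter of compound 1 (a 1.4-fold higher number from compound 1 to compound 3 (0.15 log units; within the scatter)) and well clear of compound 2 (a 4.1-fold higher number from compound 2 to compound 3 (0.62 log units; beyond the scatter)). The next change gives compound 4 `CCOC(=O)c1c(C)nc(-c2cccc(C#N)c2)n1OCc1ccc(C)cc1`: methyl in place of bromo on an aromatic carbon, para to a large group. Going by the values given here, the only measured change at this place is a 4.1-fold higher number from compound 2 to compound 3 (0.62 log units; beyond the scatter). No methyl has been measured here, so only part of that gap is expected to return. The expected size and direction are a 2.2-fold lower number from compound 3 to compound 4 (0.35 log units; beyond the scatter). For compound 4 the estimate is 11000 nM, with an expected range of 4500 nM to 26000 nM.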

Compound 4, half-maximal inhibitory concentration: 6310 nM
Estimate against measurement, compound 4: 1.7-fold (0.24 log units) above; measured number inside the range.
By their numbers in this assay, from the lowest: compounds 2 and 4 (each within the scatter of the next); then compounds 1 and 3 (each within the scatter of the next).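

Methyl at this place, para to a large group, takes back the loss seen with bromo, a 3.9-fold lower number from compound 3 to compound 4 (0.59 log units; beyond the scatter), and leaves nothing separable from the unsubstituted benzyl, a 1.1-fold higher number from compound 2 to compound 4 (0.03 log units; within the scatter). The 4-methylbenzyl group also keeps the gain over hydrogen on that oxygen, a 2.8-fold lower number from compound 1 to compound 4 (0.45 log units; beyond the scatter), so among these substituents only bromo cancels it. No evidence is available on what separates bromo from methyl here.

Open, going by these compounds, is whether chloro follows bromo at this place. Also open, on these data alone, is whether an amine, a carboxylic acid or a longer chain here stays level with methyl.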